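This account rests on a few compounds, and the source may have more. Where it says the series, first, only, none or still open, it means among the compounds named here.

The measured compounds:

Compound 1, `CC(C)[C@H](C(=O)Nc1nnc(C(F)(F)F)s1)c1ccc(Cl)cc1`, gives 1900 nM in a functional assay on CHO cells for agonist activity at Free fatty acid receptor 2 (Homo sapiens), read by cAMP accumulation; on this read-out lower numbers stand for stronger inhibition and higher numbers for weaker inhibition.
Compound 2, `COC(=O)c1cnc(NC(=O)[C@H](c2ccc(Cl)cc2)C(C)C)s1`, gives 2000 nM in this assay.
Compound 3, `CC(C)(C)[C@H](C(=O)Nc1ncc(F)s1)c1ccc(Cl)cc1`, gives 700 nM in this assay.

Among these three, compound 3 stands with the lowest number, and its gaps to compound 1 and to compound 2 both lie beyond the usual scatter of repeated measurements, so it counts as the most potent of the set. Compound 4, `CC(C)(C)[C@H](C(=O)Nc1ncc(Cc2ccc(Cl)cc2)s1)c1ccc(Cl)cc1`, is not yet measured. It differs from compound 3 in one place: 4-chlorobenzyl in place of fluoro on an aromatic carbon of the five-membered aromatic ring with one nitrogen and one sulfur. Among the compounds with values here, no measured pair in this set shows what such a change does, so there is no step to lean on. The expectation is therefore cautious: the step of a 1.1-fold higher number from compound 3 to compound 4 (0.06 log units; within the scatter) is expected to stay within the scatter, with no clear direction. Compound 4 is accordingly estimated at 800 nM in this assay, within a broad range from 150 nM to 4000 nM.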

Compound 4, half-maximal inhibitory concentration: 25000 nM
Estimate against measurement, compound 4: 31-fold (1.49 log units) below; measured number outside the range, above it.
By their numbers in this assay, from the lowest: compound 3; then compounds 1 and 2 (each within the scatter of the next); then compound 4.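

Within the data shown here, the aromatic carbon next to the ring sulfur proves sensitive to what it carries in this assay: 4-chlorobenzyl in place of fluoro gives a 36-fold higher number from compound 3 to compound 4 (1.55 log units; beyond the scatter), the only step in the set that can be read at this position. The change adds a six-membered aromatic ring of carbon and a chlorine, without any hydrogen-bond donor, hydrogen-bond acceptor or net charge on either group, so this large loss of inhibition arises without any change in those counts. Nothing given here accounts for the size of this step.

The compounds shown leave open whether a benzyl without the chlorine would behave like 4-chlorobenzyl, and how a methyl or an ethyl on this carbon would compare with fluoro. They also leave open what an amine or a carboxylic acid would do here.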